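Cyclopropyl Acrylamide in Place of a Propanoic Acid

The source may report more compounds than this note shows. Statements on the series, on what has been measured and on what is new or still open speak of the compounds shown alone.

compound 1 `CNC(=O)/C=C/c1ccncc1-c1ccc2[nH]ccc2c1`: > 10000 nM
compound 2 `CNC(=O)/C=C/c1ccncc1-c1ccc2c(cnn2C)c1`: > 10000 nM
compound 3 `O=C(O)CCc1ccncc1-c1ccc2ccccc2c1`: > 10000 nM

In a functional assay on MCF7 cells (Homo sapiens) for inhibition, read by sulforhodamine B assay, with a stated time of 72 h (a lower number here means a stronger inhibitor of growth, a higher number a weaker inhibitor of growth), compound 3 gives > 10000 nM, which is a limit of the assay and not a number. Compound 1 gives > 10000 nM, also a limit. Compound 2 gives > 10000 nM, again a limit. Compound 3 thus stands at the limit of > 10000 nM in this assay, at which 3 of the 3 values shown sit, and no measured value separates the three compounds. Compound 4 `O=C(/C=C/c1ccncc1-c1ccc2ccccc2c1)NC1CC1` has not been measured. It differs from compound 3 by 2-(cyclopropylcarbamoyl)ethenyl in place of 2-carboxyethyl on an aromatic carbon. Going by the values given here, no step between measured compounds is known here, so the expectation rests on the limits alone. The step that the limit leaves unreadable from compound 3 to compound 4 is expected to be none beyond the scatter. Compound 4 is therefore estimated at 15000 nM, within 3000 nM to 60000 nM, most likely reported again as a limit.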

Compound 4, concentration for 50% growth inhibition: 6840 nM
Estimate against measurement, compound 4: 2.2-fold (0.34 log units) above, and the stated range covers the measured number.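

Going by these compounds alone, compound 4 is the first compound here to give a number rather than a limit in this assay, so 2-(cyclopropylcarbamoyl)ethenyl at this position, opposite the ring nitrogen, brings growth inhibition into the readable range. From the compounds shown here alone, the change reads as an at least 1.4-fold lower number from compound 3 to compound 4 (0.16 log units; that floor lies within the scatter), so its true size remains unknown. The other compounds offer no number for comparison: the limit of > 10000 nM in this assay, at which 3 of the 4 values shown sit.

Still open, going by these compounds, is which part of the new group matters: the cyclopropyl ring, the double bond or the amide. A saturated 2-(cyclopropylcarbamoyl)ethyl group or a simple amine at this position would help separate these parts.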